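Swapping the Aryl Tail: From Dichlorophenyl to Methoxyphenyl

The source may report more compounds than this note shows. Statements on the series, on what has been measured and on what is new or still open speak of the compounds shown alone.

Three measured compounds share one core and differ only in the aromatic group at the end of the sulfur-linked chain. Compound 1 `C#CCNC1CCc2c(SCCc3cccc(C)c3)cccc21` gives 4960 nM in an ADME assay on isolated protein for inhibition of Amine oxidase [flavin-containing] B (Homo sapiens); on this read-out higher numbers stand for weaker inhibition and lower numbers for stronger inhibition. Compound 2 `C#CCNC1CCc2c(SCCc3ccc(C(F)(F)F)cc3)cccc21` gives 8780 nM in this assay. Compound 3 `C#CCNC1CCc2c(SCCc3ccc(Cl)c(Cl)c3)cccc21` gives 2820 nM in this assay, the lowest of the three numbers, though its gap to compound 1 is within the scatter and only its gap to compound 2 lies beyond it. Among the compounds with values here, the single step between measured neighbours, a 1.8-fold lower number from compound 1 to compound 3 (0.25 log units; within the scatter), is small. Compound 4 `C#CCNC1CCc2c(SCCc3ccc(OC)cc3)cccc21` carries the change (4-methoxyphenyl in place of 3,4-dichlorophenyl on a saturated chain carbon, two bonds along the chain from a sulfur). Within the data shown here, no measured step involves a methoxy group, so the expectation rests on how little the aromatic swaps have moved the numbers so far; the values of compound 3 and compound 2 mark the widest gap seen. Compound 4 is therefore expected to show a 1.8-fold higher number from compound 3 to compound 4 (0.25 log units; within the scatter) as its estimated step and an estimated value of 5000 nM, with a range from 2000 nM to 15000 nM.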

Compound 4, half-maximal inhibitory concentration: 4590 nM
Estimate against measurement, compound 4: 1.1-fold (0.04 log units) above, and the stated range covers the measured number.
By their numbers in this assay, from the lowest: compounds 3, 4, 1 and 2 (each within the scatter of the next, the first and the last beyond it).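

Within the data shown here, compound 4 brings the first oxygen into the aromatic tail, and with it a hydrogen-bond acceptor, yet in this assay it stays within the scatter of the earlier compounds: the step reads (a 1.6-fold higher number from compound 3 to compound 4 (0.21 log units; within the scatter)) against the dichlorophenyl tail and (a 1.1-fold lower number from compound 1 to compound 4 (0.03 log units; within the scatter)) against the methylphenyl tail. Methoxy in place of trifluoromethyl on an aromatic carbon also stays inside the scatter (a 1.9-fold lower number from compound 2 to compound 4 (0.28 log units; within the scatter)), so among these four tails only the gap between compound 3 and compound 2 lies beyond it. No supporting measurement is available to explain this result.

The compounds shown leave open how this position would respond to a phenyl ring bearing an amine or a carboxylic acid. A longer chain in place of the present one is also untested here.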